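From Furan to Oxolane on the Carbonyl Carbon

The source may report more compounds than this note shows. Statements on the series, on what has been measured and on what is new or still open speak of the compounds shown alone.

Compound 1 `O=C(Nc1ccc(OC(F)(F)F)cc1)NC1CCN(C(=O)c2ccoc2)CC1` stands second highest of the three numbers in a physicochemical assay for solubility, read by mass spectrometry, in phosphate buffer, with a stated time of 24 h, at pH 3 (a lower number here means a less soluble compound, a higher number a more soluble compound), at 26 ug/mL. Compound 3 `O=C(Nc1ccc(C(F)(F)F)cc1)NC1CCN(C(=O)C2CCOCC2)CC1` lies nearest with 61 ug/mL, and compound 2 `Cc1ccoc1C(=O)N1CCC(NC(=O)Nc2ccc(C(F)(F)F)cc2)CC1` lies furthest with 1.8 ug/mL. Compound 4 `O=C(Nc1ccc(OC(F)(F)F)cc1)NC1CCN(C(=O)C2CCOC2)CC1` differs from compound 1 in one place: oxolan-3-yl in place of furan-3-yl on a carbonyl carbon. Among the compounds with values here, one measured step bears on this, the exchange of a five-membered aromatic ring for a five-membered non-aromatic ring on the same kind of carbonyl carbon, which gave a 34-fold higher number from compound 2 to compound 3 (1.53 log units; beyond the scatter). That step also removed a methyl group, so a somewhat smaller rise is expected here, though still beyond the scatter. Compound 4 is therefore expected to give 150 ug/mL, within a range from 50 ug/mL to 500 ug/mL. The expected step amounts to a 5.8-fold higher number from compound 1 to compound 4 (0.76 log units; beyond the scatter).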

Compound 4, solubility: 91 ug/mL
Estimate against measurement, compound 4: 1.6-fold (0.22 log units) above, within the range that was stated.
By their numbers in this assay, from the lowest: compound 2; then compound 1; then compounds 3 and 4 (each within the scatter of the next).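

In this assay the exchange gave a 3.5-fold higher number from compound 1 to compound 4 (0.54 log units; beyond the scatter) while the group on the carbonyl carbon kept its ring size, heavy atoms and hydrogen-bond acceptor, so that only the aromatic ring gave way to a non-aromatic one. The earlier step also altered ring size and removed a methyl group, whereas this one did neither and still lies beyond the scatter. Nothing measured here gives a reason for the rise. On these data alone, whether the same exchange holds with trifluoromethyl in place of the trifluoromethoxy group remains open. So does what an amine or an open ether chain would give on this carbonyl carbon.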